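The compounds below may be only part of what the source reports. "The series", "measured", "known", "first", "only" and "open" are said of these compounds alone.

Compounds measured so far:
- compound 1, `CC(C)=CCc1cc(C(=O)Nc2cc3ccc(OCCCN(C)C(C)C)c(C)c3oc2=O)ccc1O`: 1050 nM
- compound 2, `COC(=O)CNCCCOc1ccc2cc(NC(=O)c3ccc(O)c(CC=C(C)C)c3)c(=O)oc2c1C`: 2820 nM

In a functional assay on MCF7 cells (Homo sapiens) for antiproliferative activity (a higher number here means a weaker inhibitor, a lower number a stronger inhibitor), compound 2 gives the highest of the two numbers recorded; its nearest neighbour is compound 1, and the difference between them is a 2.7-fold higher number from compound 1 to compound 2 (0.43 log units; beyond the scatter). Compound 3, `CC(C)=CCc1cc(C(=O)Nc2cc3ccc(OCCCN(C)Cc4ccccc4)c(C)c3oc2=O)ccc1O`, has not yet been measured. It differs from compound 2 in one place: benzyl(methyl)amino in place of ((methoxycarbonyl)methyl)amino on a saturated chain carbon, three bonds along the chain from an oxygen on an aromatic ring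

Among the compounds with values here, only one measured step bears on this change, namely a 2.7-fold higher number from compound 1 to compound 2 (0.43 log units; beyond the scatter), which shows that swapping the isopropyl(methyl)amino of compound 1 for the ((methoxycarbonyl)methyl)amino of compound 2 raised the number modestly. Compound 3 replaces that same group with benzyl(methyl)amino, so the step in this assay is expected to run the other way, back toward the number of compound 1, with an expected size of about a 2.8-fold lower number from compound 2 to compound 3 (0.45 log units; beyond the scatter). Compound 3 is therefore estimated at 1000 nM, with a range from 400 nM to 2500 nM.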

Compound 3, half-maximal inhibitory concentration: 11500 nM
Compound 3: middle estimate off by 12-fold (1.06 log units), on the low side; the whole stated range lies below it.
By their numbers in this assay, from the lowest: compound 1; then compound 2; then compound 3.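

In this assay, benzyl(methyl)amino is the least favourable of the three groups seen at this place: replacing ((methoxycarbonyl)methyl)amino with it gives a 4.1-fold higher number from compound 2 to compound 3 (0.61 log units; beyond the scatter), and replacing isopropyl with benzyl on the amine nitrogen gives an 11-fold higher number from compound 1 to compound 3 (1.04 log units; beyond the scatter), a large change where the earlier step was modest. Compound 1 and compound 3 both keep a methyl on that nitrogen yet lie at opposite ends of the series, so the methyl alone does not set the number; what the other substituent contributes is decisive here. Nothing measured here explains the rise with benzyl.

What a cyclohexylmethyl group on the same nitrogen would give stays open, so the compounds shown cannot tell whether the aromatic ring of the benzyl matters. Equally open, as far as these compounds go, are a carboxylic acid in place of the methyl ester of compound 2 and a shorter or longer chain leading to the amine.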